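The compounds below may be only part of what the source reports. "The series", "measured", "known", "first", "only" and "open" are said of these compounds alone.

Compound 1 `COc1ccc(Cc2nnc(NC(=O)/C(C#N)=C/c3ccccc3OS(=O)(=O)c3ccccc3[N+](=O)[O-])s2)cc1` is the starting point. In a functional assay on HL-60 cells (Homo sapiens) for inhibition, read by CCK-8 assay, with a stated time of 48 h, tested at 20 uM (a lower number here means less inhibition of growth, a higher number more inhibition of growth at the concentration tested), compound 1 gives 25%. Compound 2 `COc1ccc(Cc2nnc(NC(=O)/C(C#N)=C/c3ccccc3OS(=O)(=O)c3ccc(Cl)cc3)s2)cc1` carries the change (4-chlorophenyl in place of 2-nitrophenyl on a sulfonyl sulfur), and in this assay compound 2 gives 20%; the step is a number 5 percentage points lower from compound 1 to compound 2 (within the scatter). Compound 3 `N#C/C(=C\c1ccccc1OS(=O)(=O)c1ccccc1[N+](=O)[O-])C(=O)Nc1nnc(Cc2ccc(F)cc2)s1` differs from compound 1 by fluoro in place of methoxy on an aromatic carbon, and in this assay compound 3 gives 35%, which is a number 10 percentage points higher from compound 1 to compound 3 (within the scatter).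

Compound 4 `N#C/C(=C\c1ccccc1OS(=O)(=O)c1ccc(Cl)cc1)C(=O)Nc1nnc(Cc2ccc(F)cc2)s1` is not yet measured. It differs from compound 3 by 4-chlorophenyl in place of 2-nitrophenyl on a sulfonyl sulfur, the same change made from compound 1 to compound 2, at the same place; among these compounds it occurs twice in all. The two cores differ by fluoro in place of methoxy on an aromatic carbon.

The expectation for compound 4 rests on a single earlier step: the step from compound 1 to compound 2 was a number 5 percentage points lower from compound 1 to compound 2 (within the scatter), and so the step from compound 3 to compound 4 is expected to be a number 5 percentage points lower from compound 3 to compound 4 (within the scatter). On this basis compound 4 is estimated to give about 30% in this assay, between 20% and 40%.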

Compound 4, percent growth inhibition at one concentration: 20%
For compound 4 the middle estimate is 10 percentage points above the measured one; the measured number falls inside the stated range.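

In this assay, for the compounds shown here, 4-chlorophenyl in place of 2-nitrophenyl on the sulfonyl sulfur gives a number 15 percentage points lower from compound 3 to compound 4 (beyond the scatter), and the two readings of this change do not differ beyond what repeated measurements allow: the same change on two cores in this assay, a number 5 percentage points lower (within the scatter) from compound 1 to compound 2 and a number 15 percentage points lower (beyond the scatter) from compound 3 to compound 4, 10 percentage points apart, within the scatter of two such steps Fluoro in place of methoxy gives no change at the digits printed from compound 2 to compound 4 (within the scatter), and this change also reads alike in both settings: the same change on two cores in this assay, a number 10 percentage points higher (within the scatter) from compound 1 to compound 3 and no change at the digits printed (within the scatter) from compound 2 to compound 4, 10 percentage points apart, within the scatter of two such steps Within these four compounds, the sulfonyl change therefore carries from one core to the other without a demonstrable difference, but this rests on only two pairs at one tested concentration and does not show that the step has the same size on both cores or on any other core.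

The compounds shown leave open how a butyl chain on the sulfonyl sulfur, in place of either aromatic group, would read in this assay. They also leave open whether an amine or a carboxylic acid in place of fluoro or methoxy would fit the same picture.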